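Swapping Dichlorophenyl for Methoxyphenyl on the Carbonyl Carbon

The source may hold more compounds than are shown below. What is called first, only, known or untested is meant among the compounds shown, and "the series" means these compounds.

Compound 2 `COc1cc(-c2cc(/C=C/C(=O)c3ccc(Cl)c(Cl)c3)[nH]n2)cc(OC)c1OC` gives 12% in a functional assay on SNB-19 cells (Homo sapiens) for cytotoxicity, read by sulforhodamine B assay, with a stated time of 48 h, tested at 100 uM (on this read-out higher numbers stand for a weaker effect at the one concentration tested and lower numbers for a stronger effect), the highest of the three numbers at hand. Compound 1 `COc1cc(-c2cc(/C=C/C(=O)c3ccc(N)cc3)[nH]n2)cc(OC)c1OC` gives -94%, and compound 3 `COc1ccc(-c2cc(/C=C/C(=O)c3cc(OC)c(OC)c(OC)c3)[nH]n2)cc1OC` gives -77%, both far below compound 2. Among the measured compounds shown here, the one measured step touching compound 2 is a number 106 percentage points higher from compound 1 to compound 2 (beyond the scatter), a large move toward a weaker effect. Compound 4 `COc1ccc(C(=O)/C=C/c2cc(-c3cc(OC)c(OC)c(OC)c3)n[nH]2)cc1` differs from compound 2 in one place: 4-methoxyphenyl in place of 3,4-dichlorophenyl on a carbonyl carbon. Compound 3, whose group on the carbonyl carbon also bears methoxy groups, gives -77%, a much lower number. Compound 4 is therefore expected to move back toward a stronger effect, with a step estimated at a number 62 percentage points lower from compound 2 to compound 4 (beyond the scatter). Compound 4 is estimated at -50%, within a range from -100% to 10%.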

Compound 4, a percentage reported as activity, at one concentration (the size of the read-out at that concentration, not a potency): -6%
Beside the measured number, compound 4's estimate is 44 percentage points below it, within the range that was stated.
By their numbers in this assay, from the lowest: compound 1; then compound 3; then compound 4; then compound 2.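

Replacing 3,4-dichlorophenyl with 4-methoxyphenyl on a carbonyl carbon gives a number 18 percentage points lower from compound 2 to compound 4 (beyond the scatter) in this assay, whereas methoxy in place of amino on an aromatic carbon gives a number 88 percentage points higher from compound 1 to compound 4 (beyond the scatter). The number at this position therefore depends on more than the ring alone, and compound 4 lies much closer to compound 2 than to compound 1. Nothing available explains this difference.

On these data alone, it remains open whether a hydroxy group or a dimethylamino group in place of the methoxy would bring the number back toward that of compound 1.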